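The compounds below may be only part of what the source reports. "The series", "measured", "known", "first", "only" and "open" are said of these compounds alone.

Compound 1 `Cc1cccc(Cn2c(CN3CCN(C(=O)c4ccc([N+](=O)[O-])cc4)CC3)nc3ccccc32)c1` gives 24.3% in an assay on isolated protein for inhibition of aldehyde dehydrogenase 1A1 (Homo sapiens), read by spectrophotometry, tested at 10 uM; a higher number here means more inhibition at the concentration tested (going by the name of the read-out), a lower number less inhibition. Compound 2 `O=C(C1CC1)N1CCN(Cc2nc3ccccc3n2Cc2ccccc2C(F)(F)F)CC1` gives 56.3% in this assay. Compound 3 `O=C(C1CC1)N1CCN(Cc2nc3ccccc3n2Cc2ccccc2F)CC1` gives 40.7% in this assay.

Compound 1 stands lowest of the three in this assay; compound 3 lies higher and compound 2 higher still, both gaps beyond the scatter. Compound 4 `Cc1cccc(Cn2c(CN3CCN(C(=O)c4ccc(Br)cc4)CC3)nc3ccccc32)c1` differs from compound 1 in one place: bromo in place of nitro on an aromatic carbon. Among the measured compounds shown here, the only measured step, a number 15.6 percentage points lower from compound 2 to compound 3 (beyond the scatter), concerns a different part of the shared core and does not bear on an exchange of nitro for bromo; no measured pair shows that exchange. With nothing to anchor a direction, the expected step of a number 3.7 percentage points higher from compound 1 to compound 4 (within the scatter) is one within the scatter. Compound 4 is therefore estimated at 28% in this assay, with a range from 8% to 50%.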

Compound 4, a percentage reported as inhibition, at one concentration (the size of the read-out at that concentration, not a potency): 25.8%
Compound 4: middle estimate off by 2.2 percentage points, on the high side; measured number inside the range.
By their numbers in this assay, from the lowest: compounds 1 and 4 (each within the scatter of the next); then compound 3; then compound 2.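

In this assay, among the compounds shown here, bromo in place of nitro, para to a large group, gives a number 1.5 percentage points higher from compound 1 to compound 4 (within the scatter), the first reading at this position. Losing the 2 hydrogen-bond acceptors of nitro and going from 3 heavy atoms to 1 therefore leaves the two compounds within the scatter of each other. Nothing available gives a reason for this result.

Open, on these data alone, is whether an amine or a carboxylic acid at this position would separate from compound 1. Also open, as far as these compounds go, is whether the nitro-to-bromo exchange reads alike with other groups on the shared core.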